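This account rests on a few compounds, and the source may have more. Where it says the series, first, only, none or still open, it means among the compounds named here.

In a functional assay on the whole organism with Canis familiaris (Canis lupus familiaris) as the target (a lower number here means that less compound is needed, a higher number that more compound is needed for the effect), compound 1 `Cc1cccc(-c2nc3ccc[nH]c-3n2)c1` gives 2.8 mg/kg and compound 3 `c1ccc(-c2nc3cc[nH]cc-3n2)cc1` gives 2.5 mg/kg, two values within the scatter of each other. Compound 2 `COc1cc(S(C)(=O)=O)ccc1-c1nc2ccc[nH]c-2n1` gives 0.4 mg/kg, a number clearly lower than that of compound 3. Compound 4 `CS(=O)(=O)c1ccc(-c2nc3cc[nH]cc-3n2)cc1` is compound 3 with methylsulfonyl in place of hydrogen on an aromatic carbon, para to a group of 9 heavy atoms: methylsulfonyl in place of hydrogen on an aromatic carbon. Among the compounds with values here, no measured pair shows this change alone. Compound 2, at 0.4 mg/kg, also carries methylsulfonyl, although it differs from compound 4 in other places too. A lower number than that of compound 3 is therefore expected, probably beyond the scatter. The expected change is a 3.6-fold lower number from compound 3 to compound 4 (0.55 log units; beyond the scatter). For compound 4 the estimate is 0.7 mg/kg, with an expected range of 0.2 mg/kg to 2.2 mg/kg.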

Compound 4, dose for half-maximal effect: 7.5 mg/kg
For compound 4 the middle estimate is 11-fold (1.03 log units) below the measured one; measured number above the stated range.
By their numbers in this assay, from the lowest: compound 2; then compounds 3 and 1 (each within the scatter of the next); then compound 4.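

In this assay methylsulfonyl in place of hydrogen on an aromatic carbon, para to a group of 9 heavy atoms, gives a 3.0-fold higher number from compound 3 to compound 4 (0.48 log units; beyond the scatter) as a modest step. On this core and at this place, the group therefore raises the dose needed, and carrying methylsulfonyl does not by itself bring a low number. Nothing available accounts for this step. From the compounds shown here alone, it remains open whether an amine or a carboxylic acid at the same place would shift the number in the same direction. Going by these compounds, whether methylsulfonyl acts alike on the core of compound 1 also remains open.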